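The source may hold more compounds than are shown below. What is called first, only, known or untested is meant among the compounds shown, and "the series" means these compounds.

Compound 1 `C#CC(=O)N1C(c2ccccc2)SC[C@@H]1C(=O)OCC` carries a phenyl group on the five-membered core. In a functional assay on Huh-7 cells (Homo sapiens) for inhibition, read by sulforhodamine B assay (on this read-out higher numbers stand for weaker inhibition and lower numbers for stronger inhibition), compound 1 gives 5300 nM, the highest number of the three measured compounds, which means the weakest inhibition. Compound 2 `C#CC(=O)N1C(c2cccc(F)c2)SC[C@@H]1C(=O)OCC` gives 1400 nM and compound 3 `C#CC(=O)N1C(c2ccc(F)cc2)SC[C@@H]1C(=O)OCC` gives 700 nM. Adding a fluorine to the phenyl ring helps: a 3.8-fold lower number from compound 1 to compound 2 (0.58 log units; beyond the scatter) and a 7.6-fold lower number from compound 1 to compound 3 (0.88 log units; beyond the scatter), while a 2.0-fold lower number from compound 2 to compound 3 (0.30 log units; within the scatter).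

Compound 4 `C#CC(=O)N1C(C(C)(C)C)SC[C@@H]1C(=O)OCC` makes a different kind of change: tert-butyl in place of phenyl on a saturated ring carbon. Among the compounds with values here, none of the measured steps bears directly on it; all three keep the aromatic ring and only alter its fluorine, so they tell nothing about removing that ring altogether. From the compounds shown here alone, the fluorine steps do show that the ring matters to the read-out, but whether a tert-butyl group can stand in for it is untested. Within the data shown here, with no guiding step, the expectation is a 1.3-fold higher number from compound 1 to compound 4 (0.12 log units; within the scatter), with wide uncertainty. Compound 4 is therefore estimated at 7000 nM, in a range from 2000 nM to 25000 nM.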

Compound 4, half-maximal inhibitory concentration: 800 nM
Compound 4: middle estimate off by 8.8-fold (0.94 log units), on the high side, outside the stated range (below it).
By their numbers in this assay, from the lowest: compounds 3, 4 and 2 (each within the scatter of the next); then compound 1.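

An aromatic ring is not needed at this position of the core to reach a low number: in this assay, replacing phenyl with tert-butyl gives a 6.6-fold lower number from compound 1 to compound 4 (0.82 log units; beyond the scatter), so a group with no ring does as well here as adding fluorine does. Compared with the fluorinated compounds, tert-butyl cannot be told apart from either 4-fluorophenyl or 3-fluorophenyl, with a 1.1-fold higher number from compound 3 to compound 4 (0.06 log units; within the scatter) and a 1.8-fold lower number from compound 2 to compound 4 (0.24 log units; within the scatter). Nothing shown here explains why this exchange lowers the number.

The compounds shown leave open how a cyclohexyl ring or a small methyl group would behave at this position. They also leave open whether a longer chain ending in an amine or a carboxylic acid would keep the number low.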